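Methyl on an oxygen of a spleen-activating purine

A few compounds are considered here, and "the series" means these few. Any claim that something is new, unique, unknown or untested is made for them only; others in the source may bear on it.

Going by the values given here, compound 1, `Nc1nc(O)nc2c1nc(O)n2Cc1ccccc1`, is the only compound of the pair with a numerical result in a functional assay (spleen, spleen) for activation, with Mus musculus as the target; on this read-out lower numbers stand for an effect already at smaller amounts and higher numbers for an effect only at larger amounts of compound: compound 1 gives 0.1 uM. Compound 2, `NNc1nc2c(N)ncnc2n1Cc1ccccc1`, is reported only as a limit of the assay in this assay, where compound 2 gives > 10 uM. Thus the limit of > 10 uM in this assay, at which 1 of the 2 values shown sits, applies to compound 2, and no step between two measured compounds can be drawn from these two, since the structures differ in more than one place.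

Compound 3, `COc1nc(N)c2nc(O)n(Cc3ccccc3)c2n1`, has not yet been measured. It differs from compound 1 by the change (methyl in place of hydrogen on an oxygen on an aromatic ring). Among the compounds with values here, no measured step speaks to this change, so the expectation rests on compound 1 and its value of 0.1 uM alone. The step from compound 1 to compound 3 is expected as a 3.3-fold lower number from compound 1 to compound 3 (0.52 log units; beyond the scatter), beyond the usual scatter and toward an effect at smaller amounts. In this assay compound 3 is expected to give 0.03 uM, within a range from 0.003 uM to 0.3 uM.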

Compound 3, minimum effective concentration: 0.1 uM
Compound 3: middle estimate off by 3.3-fold (0.52 log units), on the low side, within the range that was stated.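

In this assay, going by these compounds alone, methyl in place of hydrogen on an oxygen on an aromatic ring gives no change at the digits printed from compound 1 to compound 3 (within the scatter), and this is the first comparison here between two compounds that differ in only one place. It shows that the hydrogen on this oxygen can be replaced by methyl with no shift beyond the usual scatter, so a free hydroxy at this place is not required for activity in the spleen read-out, as compound 3 gives 0.1 uM in this assay. Nothing among the data shown explains why the value holds when the hydroxy becomes methoxy.

This single step tells only about methyl, so a longer chain such as propyl on this oxygen could behave differently. On these data alone, how an amine or a chlorine in place of the whole hydroxy would read out also remains open.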